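Keeping stability while adding a hydroxy group

A few compounds are considered here, and "the series" means these few. Any claim that something is new, unique, unknown or untested is made for them only; others in the source may bear on it.

This set of compounds was tested in an ADME assay (liver, Mus musculus) for metabolic stability, using microsomes, with a stated time of 10 min; on this read-out higher numbers stand for a more stable compound and lower numbers for a less stable compound. Compound 1, with the structure `CCCc1cnc(N2CCC(C3Cc4c(F)c(C5=CCN(S(=O)(=O)CCC)CC5)cc(F)c4O3)CC2)nc1`, gives 80% in this assay. Compound 3, with the structure `CCCc1cnc(N2CCC(C3Cc4c(F)c(C5=CCN(S(=O)(=O)CCCO)CC5)cc(F)c4O3)CC2)nc1`, gives 82%. The two differ in one place only: hydroxy in place of hydrogen on a saturated chain carbon, three bonds along the chain from a sulfonyl sulfur. This change produced a number 2 percentage points higher from compound 1 to compound 3 (within the scatter), so the two values cannot be told apart by this measurement.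

Compound 2, with the structure `CCCc1cnc(N2CCC(C3(C)Cc4cc(C5=CCN(S(=O)(=O)CCC)CC5)ccc4O3)CC2)nc1`, gives 52%, the lowest of the three numbers. Its value lies beyond the scatter from compound 1 and from compound 3. How the core of compound 2 differs from the core of compound 1 is not broken down here.

Compound 4, with the structure `CCCc1cnc(N2CCC(C3(C)Cc4cc(C5=CCN(S(=O)(=O)CCCO)CC5)ccc4O3)CC2)nc1`, has not yet been measured in this assay. It differs from compound 2 in one place: hydroxy in place of hydrogen on a saturated chain carbon, three bonds along the chain from a sulfonyl sulfur. This is the same change that turns compound 1 into compound 3, and it sits at the same place.

The step of a number 2 percentage points higher from compound 2 to compound 4 (within the scatter) is expected, because the same change on the other core measured a number 2 percentage points higher from compound 1 to compound 3 (within the scatter). Among the measured compounds shown here, the only comparison available shows no shift beyond the scatter, and nothing in the set points to a different outcome on the core of compound 2. For compound 4 the estimate is therefore 54%, expected to lie between 40% and 68%.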

Compound 4, percent of the compound remaining: 42%
Compound 4: the middle estimate sits 12 percentage points above what was measured; low and high end bracket the measured number.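

In this assay, putting hydroxy in place of hydrogen on the propyl chain of the core of compound 2 gives a number 10 percentage points lower from compound 2 to compound 4 (within the scatter), so this measurement cannot tell these two compounds apart. Set beside the earlier step, the change reads the same on both cores as far as this measurement can tell: the same change on two cores in this assay, a number 2 percentage points higher (within the scatter) from compound 1 to compound 3 and a number 10 percentage points lower (within the scatter) from compound 2 to compound 4, 12 percentage points apart, within the scatter of two such steps. Among the compounds shown here, this means that, in this small set, propyl to 3-hydroxypropyl carried over from one core to the other without a difference that stands out from the usual scatter, but it rests on only two pairs of compounds, does not prove that the change has no effect at all, and says nothing about a third core or about any other kind of measurement.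

The compounds shown leave open how an amine, a carboxylic acid or a longer chain ending in hydroxy would read in this assay at this place on the sulfonyl chain. They also leave open whether the hydroxy group would give a similar result on a core other than the two shown here, and whether repeated measurements would narrow the uncertainty around these two steps.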